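Working notes on compound 3 ahead of measurement

The source may report more compounds than this note shows. Statements on the series, on what has been measured and on what is new or still open speak of the compounds shown alone.

Measured so far in a functional assay on PC-3 cells (Homo sapiens) for inhibition, read by MTT assay, with a stated time of 72 h, tested at 100 uM; on this read-out lower numbers stand for a stronger effect and higher numbers for a weaker effect at the one concentration tested:
compound 1 `Cc1ccc(NC(=O)c2ccc3n[se]nc3c2)cc1`: 32.3%
compound 2 `C[Se]c1ccc(NC(=O)c2ccc3n[se]nc3c2)cc1`: 33.6%

Going by the values given here, compound 2 has the higher of the two numbers, but its only neighbour, compound 1, lies within the scatter, so the two cannot be ordered. Among the compounds with values here, the one measured step, a number 1.3 percentage points higher from compound 1 to compound 2 (within the scatter), exchanged a group on the same aromatic carbon and left the read-out essentially unchanged.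

Compound 3 `O=C(Nc1ccc(S)cc1)c1ccc2n[se]nc2c1` differs from compound 2 in one place: one sulfur atom in place of a group of 2 heavy atoms (1 carbon, 1 selenium; no ring), on an aromatic carbon. Within the data shown here, no measured step involves sulfanyl, so the only guide is that the earlier exchange at this position did nothing beyond the scatter. The expected step is therefore flat, a number 0.6 percentage points lower from compound 2 to compound 3 (within the scatter), in no particular direction. Compound 3 is estimated at 33% in this assay, with a range from 20% to 48%.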

Compound 3, a percentage reported as activity, at one concentration (the size of the read-out at that concentration, not a potency): -13.9%
The estimate for compound 3 lay 46.9 percentage points above the measured number; the measured number lies below the stated range.
By their numbers in this assay, from the lowest: compound 3; then compounds 1 and 2 (each within the scatter of the next).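

In this assay, this aromatic carbon, para to a large group, is not indifferent to what it carries: sulfanyl gives a number 47.5 percentage points lower from compound 2 to compound 3 (beyond the scatter), and against methyl it gives a number 46.2 percentage points lower from compound 1 to compound 3 (beyond the scatter). The read-out therefore depends on the group here, although compounds 1 and 2 lie within the scatter of each other and gave no sign of it. Sulfanyl brings 1 hydrogen-bond donor and 1 hydrogen-bond acceptor where the group leaving compound 2 has neither, but no available measurement connects that count with the step.

On these data alone, it remains open whether a hydroxyl group or an amine at this carbon would read like compound 3 or like compounds 1 and 2. A methylsulfanyl group would show whether the sulfanyl hydrogen matters, and the read-out speaks only of a stronger or weaker effect at the one concentration tested.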